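This account rests on a few compounds, and the source may have more. Where it says the series, first, only, none or still open, it means among the compounds named here.

Measured so far:
compound 1, `Brc1ccc(C2=NN(C3=NC(c4ccccc4)CS3)C(c3ccc4ccccc4c3)C2)cc1`: 13000 nM
compound 2, `Cc1ccc(C2=NN(C3=NC(=O)CS3)C(c3cccc4ccccc34)C2)cc1`: 10000 nM

In a functional assay on BGC-823 cells (Homo sapiens) for inhibition, read by CCK-8 assay, with a stated time of 48 h (a lower number here means a stronger inhibitor, a higher number a weaker inhibitor), compound 1 gives 13000 nM and compound 2 gives 10000 nM; the two values sit within the usual scatter of each other, so neither stands apart. Among the measured compounds shown here, no two measured compounds differ in a single place, so no measured step is available as a guide. Compound 3, `Clc1ccc(C2=NN(C3=NC(c4ccccc4)CS3)C(c3ccc4ccccc4c3)C2)cc1`, differs from compound 1 by chloro in place of bromo on an aromatic carbon. An exchange of one halogen for another on the ring para to a large group is expected to shift the number little, probably not beyond the scatter. For compound 3 the estimate is 15000 nM with range 6000 nM to 40000 nM, meaning an expected step of a 1.2-fold higher number from compound 1 to compound 3 (0.06 log units; within the scatter).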

Compound 3, half-maximal inhibitory concentration: 14600 nM
The estimate for compound 3 lay 1.0-fold (0.01 log units) above the measured number; low and high end bracket the measured number.
By their numbers in this assay, from the lowest: compounds 2, 1 and 3 (each within the scatter of the next).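

Among the compounds shown here, the 4-bromophenyl to 4-chlorophenyl exchange gives a 1.1-fold higher number from compound 1 to compound 3 (0.05 log units; within the scatter) in this assay and is the first single-place step. At this position, on this core, the two halogens are not told apart. No measurement on hand offers a reason for this result.

From the compounds shown here alone, whether an amine, a carboxylic acid or a longer chain at this place would separate from compound 1 and compound 3 remains open. Also open, going by these compounds, is the contribution of each other part of the core, since compound 2 differs from compound 1 in more than one place.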